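Series notes: hydrogen in place of 3,4-difluorophenyl

A few compounds are considered here, and "the series" means these few. Any claim that something is new, unique, unknown or untested is made for them only; others in the source may bear on it.

Compound 1 `Cc1ccc(S(=O)(=O)/N=C(/CCNC2=CC(=O)c3ccccc3C2=O)Nc2ccc(F)c(F)c2)cc1` and compound 2 `COc1ccc(N/C(CCNC2=CC(=O)c3ccccc3C2=O)=N\S(=O)(=O)c2ccc(C(C)(C)C)cc2)cc1OC` share one core. Among the compounds with values here, in a functional assay on DU-145 cells (Homo sapiens) for cytotoxicity, read by MTT assay, with a stated time of 48 h (on this read-out lower numbers stand for stronger inhibition and higher numbers for weaker inhibition), compound 1 gives 12900 nM, the lower of the two numbers so far. Compound 2 gives 14500 nM in this assay, which sits within the scatter of compound 1, so no order between them is claimed. Compound 3 `Cc1ccc(S(=O)(=O)/N=C(\N)CCNC2=CC(=O)c3ccccc3C2=O)cc1` differs from compound 1 by hydrogen in place of 3,4-difluorophenyl on an amine nitrogen. Within the data shown here, no measured pair isolates this change, so the step is open; a modest loss of potency is expected rather than a gain. Compound 3 is estimated at 22000 nM in this assay, with a range of 8000 nM to 60000 nM. The expected step is a 1.7-fold higher number from compound 1 to compound 3 (0.23 log units; within the scatter).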

Compound 3, half-maximal inhibitory concentration: 30900 nM
For compound 3 the middle estimate is 1.4-fold (0.15 log units) below the measured one; low and high end bracket the measured number.
By their numbers in this assay, from the lowest: compounds 1 and 2 (each within the scatter of the next); then compound 3.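

In this assay hydrogen in place of 3,4-difluorophenyl on an amine nitrogen gives a 2.4-fold higher number from compound 1 to compound 3 (0.38 log units; beyond the scatter) and lies beyond the scatter. Within the data shown here, this is the first step that isolates a single position, and it shows that removing this aryl group weakens the read-out only modestly. No measurement on hand accounts for the step.

As far as these compounds go, whether a plain phenyl, a benzyl or a methyl on this nitrogen would stay closer to compound 1 or to compound 3 remains open. From the compounds shown here alone, the contribution of the two fluorines apart from the ring also remains open.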